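This account rests on a few compounds, and the source may have more. Where it says the series, first, only, none or still open, it means among the compounds named here.

Measured compounds:
compound 1 `O=C(O)/C=C/c1ccncc1-c1ccc2cc[nH]c2c1`: in a functional assay on HCT-116 cells (Homo sapiens) for inhibition, read by MTT assay, with a stated time of 72 h (on this read-out higher numbers stand for weaker inhibition of growth and lower numbers for stronger inhibition of growth), compound 1 gives > 30000 nM
compound 2 `COc1ccc(-c2cnccc2/C=C/C(=O)N2CC(OC)C2)cc1OC`: in this assay compound 2 gives "not determined" (no result reported)

The result for compound 1 is a limit of the assay, not a number (the limit of > 30000 nM in this assay, at which 1 of the 2 values shown sits), so compound 1 stands only at the weak end of what was measured, and compound 2 adds no number. Compound 3 `O=C(/C=C/c1ccncc1-c1ccc2cc[nH]c2c1)N1CCOCC1` differs from compound 1 in one place: morpholin-4-yl in place of hydroxy on a carbonyl carbon. Within the data shown here, with no measured pair of this kind to lean on, the step is expected to go toward stronger inhibition, of the size an at least 3.7-fold lower number from compound 1 to compound 3 (0.57 log units; beyond the scatter). Compound 3 is therefore estimated at 8000 nM, in the range 1500 nM to 30000 nM.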

Compound 3, concentration for 50% growth inhibition: > 30000 nM
Compound 3 ended at the assay's limit; the forecaster's own chance of this, stated with the estimate: 40%; middle value at least 3.7-fold (0.57 log units) from the limit.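

Among these compounds, compound 1 and compound 3 both end at a limit in this assay rather than at a number, so no step between them can be read: the limit of > 30000 nM in this assay, at which 2 of the 3 values shown sit. From the compounds shown here alone, whether morpholin-4-yl in place of hydroxy changes inhibition of growth at all stays open.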